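Amino for hydrogen on the shared core, second pairing

A few compounds are considered here, and "the series" means these few. Any claim that something is new, unique, unknown or untested is made for them only; others in the source may bear on it.

Compound 1 `ClCc1ccc(Cn2cnc3c(Cl)ncnc32)cc1` and compound 3 `ClCc1ccccc1Cn1cnc2c(Cl)ncnc21` are built from the same atoms joined differently; the difference between the two cores is not broken down here. In a functional assay on NCI-H226 cells (Homo sapiens) for cytotoxicity, read by sulforhodamine B assay, with a stated time of 48 h (a lower number here means that less compound is tolerated, a higher number that more compound is tolerated), compound 1 gives 49000 nM and compound 3 gives 38900 nM, two numbers within the usual scatter of each other. Compound 2 `Nc1nc(Cl)c2ncn(Cc3ccc(CCl)cc3)c2n1` carries the change amino in place of hydrogen on an aromatic carbon on the core of compound 1. In this assay compound 2 reaches > 100000 nM, which is a limit of the assay and not a number, namely (the limit of > 100000 nM in this assay, at which 1 of the 3 values shown sits). The measured step is an at least 2.0-fold higher number from compound 1 to compound 2 (0.30 log units; that floor lies within the scatter), and since its floor lies within the scatter, its true size is open upward.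

Compound 4 `Nc1nc(Cl)c2ncn(Cc3ccccc3CCl)c2n1` carries the change amino in place of hydrogen on an aromatic carbon on the core of compound 3; the surroundings of the entering group are the same in both pairs, so this is the same change made a second time. Resting on an at least 2.0-fold higher number from compound 1 to compound 2 (0.30 log units; that floor lies within the scatter), compound 4 is expected to move by a 2.4-fold higher number from compound 3 to compound 4 (0.39 log units; beyond the scatter). In this assay compound 4 is estimated at 95000 nM, with a range from 40000 nM to 250000 nM, and a real chance that only a limit is reported.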

Compound 4, concentration lethal to 50% of the cells: 53700 nM
Beside the measured number, compound 4's estimate is 1.8-fold (0.25 log units) above it, and the stated range covers the measured number.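

Made on the second core, amino in place of hydrogen on an aromatic carbon gives, in this assay, a 1.4-fold higher number from compound 3 to compound 4 (0.14 log units; within the scatter), so on this core the change stays within the usual scatter. Set beside the first pairing, the two steps cannot be told apart: the same change on two cores in this assay, an at least 2.0-fold higher number (0.30 log units; that floor lies within the scatter) from compound 1 to compound 2 and a 1.4-fold higher number (0.14 log units; within the scatter) from compound 3 to compound 4; the limit leaves it open whether they differ. Among these compounds, the two pairings therefore do not show that the change has the same size on both cores, nor that its size depends on the core; they show only that the one fully measured step, on the core of compound 3, is small enough to lie within the scatter.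

Open, from the compounds shown here alone, is how a methylamino or a hydroxyl group would behave in place of amino at this same aromatic carbon, between two ring nitrogen atoms. Also open, going by these compounds, is whether the step would hold on a core in which a methoxy group stands in place of the chloro group.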